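Replacing the fluorophenyl arm of compound 2 with chloro

The source may report more compounds than this note shows. Statements on the series, on what has been measured and on what is new or still open speak of the compounds shown alone.

Three amides share a pyridine-carboxamide linkage to a bicyclic amine. Compound 1 `Cc1cc(-c2ccccc2)ncc1C(=O)Nc1ccc2cccnc2c1` in an in vitro functional assay on 1321-N1 cells for antagonist activity at transient receptor potential cation channel subfamily V member 1 (Homo sapiens), read by FLIPR and calcium flux (a higher number here means a more potent compound, by a factor of ten per unit of this negative logarithm, a lower number a less potent compound), gives 6.7. Compound 2 `O=C(Nc1ccc2cccnc2c1)c1ccc(-c2cccc(F)c2)nc1` in this assay gives 8.6, the highest of the three and beyond the scatter from both others. Compound 3 `Cc1nc2ccc(NC(=O)c3ccc(-c4ccc(F)cc4)nc3C)cc2[nH]1` in this assay gives 6, the furthest from compound 2. No single-point pairs exist among these three, so no measured step is available to calibrate the change below; the values are only compared as they stand.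

Compound 4 `O=C(Nc1ccc2cccnc2c1)c1ccc(Cl)nc1` differs from compound 2 in one place: chloro in place of 3-fluorophenyl on an aromatic carbon. The aryl arm of compound 2 is thus removed and a single halogen atom takes its position on the aromatic carbon next to the ring nitrogen. Going by the values given here, with no measured pair of this kind, the expectation rests on the size of the group removed relative to the rest of compound 2. The step from compound 2 to compound 4 is expected to be a clear loss, a number 2.10 log units lower from compound 2 to compound 4 (beyond the scatter), beyond the scatter. Compound 4 is therefore estimated at 6.5, within a range from 5.5 to 7.5.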

Compound 4, negative logarithm of the antagonist equilibrium constant: < 6.7
Compound 4 ended at the assay's limit; the forecaster's own chance of this, stated with the estimate: 15%; the middle value lies beyond the limit too.
By their numbers in this assay, from the lowest: compound 3; then compound 1; then compound 2.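

In this assay, going by these compounds alone, chloro in place of 3-fluorophenyl on the aromatic carbon next to the ring nitrogen gives a number at least 1.90 log units lower from compound 2 to compound 4 (beyond the scatter), the first measured step at this position. Compound 1 and compound 3 each differ from compound 2 in more than one place, whereas here this one group alone separates the two compounds. The value of compound 4, < 6.7, is a limit of this assay and not a number, so the step gives only a minimum size: the limit of < 6.7 in this assay, at which 1 of the 4 values shown sits.

Going by these compounds, the full size of the step remains open, as does whether it follows the aromatic ring as a whole or the fluorine on it. An amine, a methoxy group or a short alkyl chain at this position would show how much of the potency of compound 2 survives without an aryl arm.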